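Replacing a Carboxymethyl Group on the Shared Core

The source may report more compounds than this note shows. Statements on the series, on what has been measured and on what is new or still open speak of the compounds shown alone.

compound 1 `N#CC1=C(NCC(=O)O)N(c2ccccc2)C(=O)N2CCCCC(N3CCCC3)C12`: 53.4%
compound 2 `N#Cc1c2n(c(=O)n(-c3ccccc3)c1=N)CCCCC2N1CCCC1`: 65.3%

In a functional assay on the whole organism (strain albino) for inhibition, with Rattus norvegicus as the target, read by paw edema, with stated times of 1 h and 3 h, at a dose of 12 mmol/kg by the intraperitoneal route (on this read-out lower numbers stand for a weaker effect and higher numbers for a stronger effect at the one dose given), compound 1 gives 53.4%, the lowest of the two numbers shown. Compound 2 gives 65.3% in this assay, a number higher by more than the usual scatter. Compound 3 `CCOC(=O)C(=O)NC1=C(C#N)C2C(N3CCCC3)CCCCN2C(=O)N1c1ccccc1` differs from compound 1 in one place: (ethoxycarbonyl)carbonyl in place of carboxymethyl on an amine nitrogen. Among the compounds with values here, no step between measured compounds matches this change, so there is nothing to set its size by. In this assay compound 3 is expected to give 55%, with a range from 35% to 72%. The step of a number 1.6 percentage points higher from compound 1 to compound 3 (within the scatter) is thus expected to stay within the scatter, in no clear direction.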

Compound 3, a percentage reported as inhibition, in the whole organism at one dose (the size of the read-out at that dose, not a potency): 56.2%
The estimate for compound 3 lay 1.2 percentage points below the measured number, within the range that was stated.
By their numbers in this assay, from the lowest: compounds 1, 3 and 2 (each within the scatter of the next, the first and the last beyond it).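

In this assay, (ethoxycarbonyl)carbonyl in place of carboxymethyl on an amine nitrogen gives a number 2.8 percentage points higher from compound 1 to compound 3 (within the scatter). At this one dose, therefore, the amine nitrogen carries either group, with or without the hydrogen-bond donor of carboxymethyl, and no difference can be told from the scatter. Nothing measured here bears on why the two groups read alike. Going by these compounds, whether a plain acetyl group or a longer alkyl chain on this nitrogen would read differently stays open, as does the ethyl ester of the carboxymethyl group itself.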